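This account rests on a few compounds, and the source may have more. Where it says the series, first, only, none or still open, it means among the compounds named here.

Measured compounds:
compound 1, `CCc1ccc(Nc2cc(NC(=O)Nc3cc(OC)cc(OC)c3)ncn2)cc1`, gives 23.5% in a functional assay on NCI-H520 cells (Homo sapiens) for inhibition, read by MTT assay, with a stated time of 48 h, tested at 10 uM; on this read-out lower numbers stand for less inhibition and higher numbers for more inhibition at the one concentration tested (going by the name of the read-out)
compound 2, `COc1cc(NC(=O)Nc2cc(Nc3ccc(F)c(Cl)c3)ncn2)cc(OC)c1`, gives 25.5%
compound 3, `O=C(Nc1cc(Nc2ccc(F)c(Cl)c2)ncn1)Nc1c(Cl)cccc1Cl`, gives 39.5%

Compound 3 stands highest of the three in this assay, with compound 2 nearest and compound 1 furthest, both beyond the scatter. The difference between the core of compound 3 and the core of compound 2 is not broken down here. Compounds 2 and 1 differ only by 4-ethylphenyl in place of 3-chloro-4-fluorophenyl on a nitrogen on an aromatic ring, and that step reads a number 2 percentage points lower from compound 2 to compound 1 (within the scatter).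

Compound 4, `CCc1ccc(Nc2cc(NC(=O)Nc3c(Cl)cccc3Cl)ncn2)cc1`, is not yet measured. It differs from compound 3 by 4-ethylphenyl in place of 3-chloro-4-fluorophenyl on a nitrogen on an aromatic ring, the same change as from compound 2 to compound 1, at the same place. On that one earlier step, the expected step in this assay is a number 2 percentage points lower from compound 3 to compound 4 (within the scatter). Compound 4 is therefore estimated at 37.5%, expected between 26% and 49%.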

Compound 4, a percentage reported as inhibition, at one concentration (the size of the read-out at that concentration, not a potency): 31.5%
Compound 4: the middle estimate sits 6 percentage points above what was measured; low and high end bracket the measured number.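

The change to 4-ethylphenyl from 3-chloro-4-fluorophenyl in this assay reads a number 8 percentage points lower from compound 3 to compound 4 (within the scatter). Set beside the earlier step, it carries across these two cores with no difference that can be told apart, and neither step goes beyond the scatter: the same change on two cores in this assay, a number 2 percentage points lower (within the scatter) from compound 2 to compound 1 and a number 8 percentage points lower (within the scatter) from compound 3 to compound 4, 6 percentage points apart, within the scatter of two such steps This rests on two pairs at one concentration in one cell line, so it does not show that the change would behave alike on other cores, and it says nothing about potency.

Still open, as far as these compounds go, is how other groups on that nitrogen would read, such as a phenyl ring carrying a longer chain, an amine or a carboxylic acid. Also open, from the compounds shown here alone, is whether the agreement between the two steps holds at other concentrations.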